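Anilide series: sulfamoyl in place of hydroxy(phenyl)methyl

A few compounds are considered here, and "the series" means these few. Any claim that something is new, unique, unknown or untested is made for them only; others in the source may bear on it.

Measured so far:
- compound 1 `Cn1nnnc1-c1ccc(NC(=O)C(C)(O)C(F)(F)F)cc1` — 30900 nM
- compound 2 `CC(O)(C(=O)Nc1ccc(S(=O)(=O)N2CCOCC2)cc1)C(F)(F)F` — 5850 nM
- compound 3 `CC(O)(C(=O)Nc1ccc([C@@H](O)c2ccccc2)cc1)C(F)(F)F` — > 30000 nM

Compound 3 stands at a limit of the assay in an assay on a protein complex (Cavia porcellus) with sulfonylurea receptors; K-ATP channels (Homo sapiens) as the target (on this read-out lower numbers stand for stronger inhibition and higher numbers for weaker inhibition), namely > 30000 nM; no number is known for it. Among the compounds with values here, the step that the limit leaves unreadable from compound 1 to compound 3 is therefore unreadable in size because of the limit of > 30000 nM in this assay, at which 1 of the 3 values shown sits, and it is the only measured step that bears on the present change.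

The change from compound 3 to compound 4 `CC(O)(C(=O)Nc1ccc(S(N)(=O)=O)cc1)C(F)(F)F` is sulfamoyl in place of hydroxy(phenyl)methyl on an aromatic carbon. The entering group sits para to a large group, as the hydroxy(phenyl)methyl did. Within the data shown here, no measured step follows this exchange directly. Among the measured compounds shown here, compound 2 carries a different sulfonyl substituent on the same aromatic carbon and gives 5850 nM in this assay, while compound 1 with its tetrazole gives 30900 nM; these two values only show that substituents of this kind span a broad range here, and no step between compound 2 and compound 4 has been measured.

Compound 4 is expected at 15000 nM, within 3000 nM to 60000 nM. The expected step from compound 3 to compound 4 is an at least 2.0-fold lower number from compound 3 to compound 4 (0.30 log units; that floor lies within the scatter), which cannot be fixed against a limit.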

Compound 4, half-maximal inhibitory concentration: 12800 nM
Estimate against measurement, compound 4: 1.2-fold (0.07 log units) above; the range from low to high includes it.
By their numbers in this assay, from the lowest: compound 2; then compound 4; then compound 1.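

In this assay, sulfamoyl on this aromatic carbon gives a readable value where hydroxy(phenyl)methyl left only a limit, with an at least 2.3-fold lower number from compound 3 to compound 4 (0.36 log units; beyond the scatter). The group on the sulfonyl sulfur also counts: exchanging morpholin-4-yl for amino gives a 2.2-fold higher number from compound 2 to compound 4 (0.34 log units; beyond the scatter), so the sulfonyl unit alone does not set the value, and the larger morpholin-4-yl form keeps the lower number of this pair. Against the tetrazole, sulfamoyl gives a 2.4-fold lower number from compound 1 to compound 4 (0.38 log units; beyond the scatter), and the three readable compounds now run in the order compound 2, compound 4, compound 1, with both gaps in that order modest and beyond the scatter.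

From the compounds shown here alone, the step from compound 3 stays a floor, and the step from compound 1 to compound 3 cannot be read: the limit of > 30000 nM in this assay, at which 1 of the 4 values shown sits. Still open is whether a dimethylamino or a piperidin-1-yl group on the sulfonyl sulfur would extend the difference between compound 2 and compound 4, and whether a carboxylic acid or a methylsulfonyl group on the same aromatic carbon would stay within the range of these sulfonyl compounds.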